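A few compounds are considered here, and "the series" means these few. Any claim that something is new, unique, unknown or untested is made for them only; others in the source may bear on it.

Three compounds have been measured in a functional assay on U-251 cells (Homo sapiens); on this read-out lower numbers stand for stronger inhibition of growth and higher numbers for weaker inhibition of growth:

Compound 1 `Cc1cc(C)c2c(O)cc(-c3ccc(Cl)cc3)nc2n1` gives 30200 nM.
Compound 2 `COc1ccc(-c2cc(O)c3c(C)cc(C)nc3n2)cc1` gives 91200 nM.
Compound 3 `Cc1cnc2nc(-c3ccc(Cl)cc3)cc(O)c2c1` gives 3020 nM.

Compound 1 and compound 2 share the same core and differ in one place only: methoxy in place of chloro on an aromatic carbon. This single change weakened growth inhibition by a modest amount, a 3.0-fold higher number from compound 1 to compound 2 (0.48 log units; beyond the scatter). Compound 3 carries a different core; how its core differs from that of compound 1 is not broken down here. Among the three, compound 3 gives the lowest number, and its gaps to compound 1 and to compound 2 both lie beyond the usual scatter.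

Compound 4 `COc1ccc(-c2cc(O)c3cc(C)cnc3n2)cc1` has not yet been measured. It is related to compound 3 exactly as compound 2 is related to compound 1, by the same change at the same kind of place: methoxy in place of chloro on an aromatic carbon. If this change behaves on the core of compound 3 as it did on the core of compound 1, the number for compound 4 is expected to rise by about as much, a step of a 3.0-fold higher number from compound 3 to compound 4 (0.47 log units; beyond the scatter), resting on the earlier step of a 3.0-fold higher number from compound 1 to compound 2 (0.48 log units; beyond the scatter). Compound 4 is therefore estimated at 9000 nM in this assay, most likely between 3000 nM and 27000 nM.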

Compound 4, concentration for 50% growth inhibition: 4170 nM
The estimate for compound 4 lay 2.2-fold (0.33 log units) above the measured number; the measured number falls inside the stated range.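

In this assay, putting methoxy in place of chloro on the core of compound 3 gave a 1.4-fold higher number from compound 3 to compound 4 (0.14 log units; within the scatter) and so cannot be told apart from no change on this core. Set beside the same change on the core of compound 1, the new step does not differ from the earlier one by more than two such steps would be expected to scatter: the same change on two cores in this assay, a 3.0-fold higher number (0.48 log units; beyond the scatter) from compound 1 to compound 2 and a 1.4-fold higher number (0.14 log units; within the scatter) from compound 3 to compound 4, 2.2-fold (0.34 log units) apart, within the scatter of two such steps

The change can therefore be said to have carried across these two cores without a detectable difference, but this rests on just two pairs of compounds, and it does not settle whether methoxy truly weakens growth inhibition on the core of compound 3 or whether the same would hold on any further core.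

The compounds shown compare only chloro and methoxy on this aromatic carbon, para to a large group. On these data alone, how an amine, a carboxylic acid or a longer chain at that place would behave on either core remains open.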